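Compound 4: a 2-methoxyphenyl urea

The source may report more compounds than this note shows. Statements on the series, on what has been measured and on what is new or still open speak of the compounds shown alone.

- compound 1 `COc1cc2c(Oc3ccc(NC(=O)Nc4ccc(OC(F)(F)F)cc4)cc3)ccnc2cc1OCCCCCCC(=O)NO` gives 3200 nM
- compound 2 `COc1cc2c(Oc3ccc(NC(=O)Nc4ccccc4C(F)(F)F)cc3)ccnc2cc1OCCCCCCC(=O)NO` gives 1080 nM
- compound 3 `COc1cc2c(Oc3ccc(NC(=O)Nc4ccc(Cl)c(C(F)(F)F)c4)cc3)ccnc2cc1OCCCCCCC(=O)NO` gives 5150 nM

In a functional assay on MCF7 cells (Homo sapiens) for antiproliferative activity, read by MTT assay (on this read-out higher numbers stand for weaker inhibition and lower numbers for stronger inhibition), compound 3 (5150 nM) sits with compound 1 (3200 nM) at the upper end of the numbers, the two lying within the scatter of each other. The remaining gap is larger (a 4.8-fold higher number from compound 2 to compound 3 (0.68 log units; beyond the scatter)). Compound 4 `COc1ccccc1NC(=O)Nc1ccc(Oc2ccnc3cc(OCCCCCCC(=O)NO)c(OC)cc23)cc1` carries 2-methoxyphenyl in place of 4-chloro-3-(trifluoromethyl)phenyl on an amide-type nitrogen. Its entering group most resembles the 2-(trifluoromethyl)phenyl of compound 2 (1080 nM), a single precedent whose steps were modest (a 3.0-fold lower number from compound 1 to compound 2 (0.47 log units; beyond the scatter)). A modest drop is therefore expected, smaller than that precedent's full gap (a 2.6-fold lower number from compound 3 to compound 4 (0.41 log units; beyond the scatter)). Compound 4 is estimated at 2000 nM (range 800 nM to 5500 nM).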

Compound 4, half-maximal inhibitory concentration: 6280 nM
Estimate against measurement, compound 4: 3.1-fold (0.50 log units) below; the measured number lies above the stated range.
By their numbers in this assay, from the lowest: compound 2; then compounds 1, 3 and 4 (each within the scatter of the next).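

In this assay, a substituent on the same 2-position of the phenyl ring does not by itself carry the lower number: methoxy in place of trifluoromethyl gives (a 5.8-fold higher number from compound 2 to compound 4 (0.76 log units; beyond the scatter)). Against the other two ureas the change reads (a 1.2-fold higher number from compound 3 to compound 4 (0.09 log units; within the scatter)) and (a 2.0-fold higher number from compound 1 to compound 4 (0.29 log units; within the scatter)), both within the scatter, so among these four only compound 2 stands apart. No supporting measurement is available to explain this. From the compounds shown here alone, whether a 2-chlorophenyl or 2-aminophenyl urea would side with compound 2 or with compound 4 remains open.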